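Swapping a Methyl for Chlorophenyl on the Amine Nitrogen

A few compounds are considered here, and "the series" means these few. Any claim that something is new, unique, unknown or untested is made for them only; others in the source may bear on it.

Three compounds sharing one core were tested in a functional assay on the whole organism for inhibition, with Rattus norvegicus as the target, with a stated time of 2 h, at a dose of 100 mg/kg by the oral route; on this read-out higher numbers stand for more inhibition at the one dose given (going by the name of the read-out) and lower numbers for less inhibition. Compound 1 `Cc1nnc(-c2nsc3ccccc23)o1` gives 43%, compound 2 `Clc1ccc(-c2nnc(-c3nsc4ccccc34)o2)cc1` gives 13%, and compound 3 `CNc1nnc(-c2nsc3ccccc23)o1` gives 10%. Compound 3 sits at the low end, within the scatter of compound 2 and well below compound 1, as a number 33 percentage points lower from compound 1 to compound 3 (beyond the scatter) shows. Compound 4 `Clc1ccc(Nc2nnc(-c3nsc4ccccc34)o2)cc1` differs from compound 3 by 4-chlorophenyl in place of methyl on a nitrogen on an aromatic ring. Within the data shown here, the one measured step of the same kind, on an aromatic carbon rather than a nitrogen, is a number 30 percentage points lower from compound 1 to compound 2 (beyond the scatter), a drop. Because 10% already leaves little room, only a small further fall, or no change beyond the scatter, is expected: a number 3 percentage points lower from compound 3 to compound 4 (within the scatter). Compound 4 is estimated at 7%, within 0% to 20%.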

Compound 4, a percentage reported as inhibition, in the whole organism at one dose (the size of the read-out at that dose, not a potency): 14%
Estimate against measurement, compound 4: 7 percentage points below, within the range that was stated.
By their numbers in this assay, from the lowest: compounds 3, 2 and 4 (each within the scatter of the next); then compound 1.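

With 4-chlorophenyl in place of methyl on a nitrogen on an aromatic ring, this assay shows a number 4 percentage points higher from compound 3 to compound 4 (within the scatter) and so no change that can be told from scatter. The same exchange on an aromatic carbon gave a number 30 percentage points lower from compound 1 to compound 2 (beyond the scatter) and that drop does not appear at this nitrogen, although compound 3 already left little room to fall. No measured evidence explains this contrast. Still open, as far as these compounds go, is whether a plain amine or a longer chain such as butyl on the shared core would bring the inhibition back towards that of compound 1.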